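Ester Removal in a Triazole Series: Cell Growth Inhibition

This account rests on a few compounds, and the source may have more. Where it says the series, first, only, none or still open, it means among the compounds named here.

The three measured compounds, each tested in a functional assay on CCRF-CEM cells (Homo sapiens) for inhibition, read by MTT assay, with a stated time of 2 days, tested at 10 uM; a higher number here means more inhibition at the concentration tested (going by the name of the read-out), a lower number less inhibition:
Compound 1 `O=C(OCCCc1ccccc1)c1cc(-n2cc(-c3cccc(O)c3)nn2)ccc1O` gives 9%.
Compound 2 `COc1ccccc1-c1cn(-c2ccc(O)c(C(=O)OCCCc3ccccc3)c2)nn1` gives 4%.
Compound 3 `O=C(O)c1cc(-n2cc(-c3cccc(O)c3)nn2)ccc1O` gives 3%.

All three numbers are low, and none of the gaps between them lies beyond the scatter of this assay. Compound 2 differs from compound 1 in its core: 2-methoxyphenyl in place of 3-hydroxyphenyl on an aromatic carbon. That exchange gives a number 5 percentage points lower from compound 1 to compound 2 (within the scatter). Compound 3 differs from compound 1 at the ester: hydrogen in place of 3-phenylpropyl on an oxygen next to a carbonyl group. That exchange gives a number 6 percentage points lower from compound 1 to compound 3 (within the scatter).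

Compound 4 `COc1ccccc1-c1cn(-c2ccc(O)c(C(=O)O)c2)nn1` has not yet been measured. It stands to compound 2 as compound 3 stands to compound 1: hydrogen in place of 3-phenylpropyl on an oxygen next to a carbonyl group. The place is worded identically in both cases, so it is the same change, made on the core of compound 2 instead of the core of compound 1. Within the data shown here, the only precedent is the step from compound 1 to compound 3, and it was within the scatter; nothing in these data shows the 2-methoxyphenyl core behaving differently from the 3-hydroxyphenyl core under this change, since the step from compound 1 to compound 2 was also within the scatter.

The step from compound 2 to compound 4 is therefore expected to be a number 3 percentage points lower from compound 2 to compound 4 (within the scatter), set beside a number 6 percentage points lower from compound 1 to compound 3 (within the scatter). Compound 4 is estimated at 1%, with a range from -6% to 9% in this assay.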

Compound 4, a percentage reported as inhibition, at one concentration (the size of the read-out at that concentration, not a potency): 9%
Estimate against measurement, compound 4: 8 percentage points below; measured number inside the range.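

In this assay, hydrogen in place of 3-phenylpropyl on an oxygen next to a carbonyl group gives a number 5 percentage points higher from compound 2 to compound 4 (within the scatter). Set side by side, the two readings of this change point in opposite directions on paper, yet they cannot be told apart: the same change on two cores in this assay, a number 6 percentage points lower (within the scatter) from compound 1 to compound 3 and a number 5 percentage points higher (within the scatter) from compound 2 to compound 4, 11 percentage points apart, within the scatter of two such steps. This shows that, on these two cores, the change leaves no effect that can be separated from the scatter, and that nothing here marks the two cores as responding differently; it does not show that the change carries a fixed size or direction from one core to another, nor that the two cores would respond alike on a core with a larger number.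

The compounds shown leave open whether another group on that oxygen, such as a methyl, a longer chain than 3-phenylpropyl, or an amide in place of the ester, would give a number that stands clear of the scatter. They also leave open how the same exchange would read on a core bearing an amine, where the starting number might be large enough for a step to be seen at all.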